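A Pyridinyl Switch Tested on a Second Core

The source may report more compounds than this note shows. Statements on the series, on what has been measured and on what is new or still open speak of the compounds shown alone.

Compound 1 `Nc1ccccc1NC(=O)c1ccc(CSC(=S)N2CCN(Cc3ccncc3)CC2)cc1` and compound 2 `Nc1ccccc1NC(=O)c1ccc(CSC(=S)N2CCN(Cc3cccnc3)CC2)cc1` share one core. In a functional assay on A-375 cells (Homo sapiens) for antiproliferative activity, read by CCK-8 assay, with a stated time of 72 h, tested at 8 uM (on this read-out lower numbers stand for a weaker effect and higher numbers for a stronger effect at the one concentration tested), compound 1 gives 89.5%, and compound 2 gives 89.2%, so the change pyridin-3-yl in place of pyridin-4-yl on a saturated chain carbon bound to an amine nitrogen in a ring produced a step of a number 0.3 percentage points lower from compound 1 to compound 2 (within the scatter). Compound 3 `CN(Cc1ccncc1)C(=S)SCc1ccc(C(=O)Nc2ccccc2N)cc1` carries a different core; the difference between the two cores is not broken down here. In this assay compound 3 gives 86.1%, within the scatter of compound 1 and compound 2. Compound 4 `CN(Cc1cccnc1)C(=S)SCc1ccc(C(=O)Nc2ccccc2N)cc1` is compound 3 after the same kind of change, (pyridin-3-yl in place of pyridin-4-yl on a saturated chain carbon bound to an amide-type nitrogen); the place is now a saturated chain carbon bound to an amide-type nitrogen rather than to an amine nitrogen in a ring. Because the earlier step of a number 0.3 percentage points lower from compound 1 to compound 2 (within the scatter) stayed within the scatter, the expected step is a number 1.1 percentage points lower from compound 3 to compound 4 (within the scatter). Compound 4 is therefore estimated at 85%, between 75% and 92%.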

Compound 4, a percentage reported as inhibition, at one concentration (the size of the read-out at that concentration, not a potency): 83.8%
The estimate for compound 4 lay 1.2 percentage points above the measured number, and the stated range covers the measured number.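

In this assay the switch from pyridin-4-yl to pyridin-3-yl on the core of compound 3 gave a number 2.3 percentage points lower from compound 3 to compound 4 (within the scatter). Set beside the same change on the core of compound 1, the two steps do not differ: the same change on two cores in this assay, a number 0.3 percentage points lower (within the scatter) from compound 1 to compound 2 and a number 2.3 percentage points lower (within the scatter) from compound 3 to compound 4, 2 percentage points apart, within the scatter of two such steps. This shows that the change left the read-out within the scatter on both cores, but it does not show that the cores would respond alike in potency, as each compound was read at one concentration, and two cores cannot speak for the whole series.

The compounds shown leave open how a pyridin-2-yl or a plain phenyl group would read at this place on either core. They also leave open whether a longer chain carrying the pyridine ring would shift the number.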